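This account rests on a few compounds, and the source may have more. Where it says the series, first, only, none or still open, it means among the compounds named here.

Compound 3 `COc1ncnc2c1c(-c1ccco1)cn2[C@@H]1O[C@H](CO)[C@@H](O)[C@H]1O` gives 430 nM in an ADME assay on BJ cells (Homo sapiens), read by MTT assay, with a stated time of 72 h (a lower number here means a stronger inhibitor, a higher number a weaker inhibitor), the lowest of the two numbers seen so far. Compound 1 `COc1ncnc2c1c(I)cn2[C@@H]1O[C@H](CO)[C@@H](O)[C@H]1O` gives 91000 nM in this assay. Compound 2 `COc1ncnc2c1c(-c1ccccc1)cn2[C@@H]1O[C@H](CO)[C@@H](O)[C@H]1O` reaches only the limit > 100000 nM in this assay (the limit of > 100000 nM in this assay, at which 1 of the 3 values shown sits). The step of a 210-fold lower number from compound 1 to compound 3 (2.33 log units; beyond the scatter) and the step of an at least 230-fold lower number from compound 2 to compound 3 (2.36 log units; beyond the scatter) show that a furan-2-yl group brings a far lower number than either iodo or phenyl at the same carbon. Compound 4 `COc1ncnc2c1c(-c1cc3ccccc3o1)cn2[C@@H]1O[C@H](CO)[C@@H](O)[C@H]1O` carries the change 1-benzofuran-2-yl in place of furan-2-yl on an aromatic carbon: the five-membered aromatic ring with one hetero atom stays, and a six-membered aromatic ring of carbon only is added to it. Among the measured compounds shown here, no measured step tests such an extension of the furan, so the number for compound 4 is expected to stay near that of compound 3, with wide uncertainty. For compound 4 the estimate is 800 nM, expected between 120 nM and 6000 nM, which means an expected step of a 1.9-fold higher number from compound 3 to compound 4 (0.27 log units; within the scatter).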

Compound 4, half-maximal inhibitory concentration: 22400 nM
The estimate for compound 4 lay 28-fold (1.45 log units) below the measured number; measured number outside the range, above it.
By their numbers in this assay, from the lowest: compound 3; then compound 4; then compound 1. At a limit, above all of these: compound 2.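

Adding a six-membered aromatic ring of carbon only to the furan gives a 52-fold higher number from compound 3 to compound 4 (1.72 log units; beyond the scatter), so the five-membered aromatic ring with one hetero atom does not by itself secure the low number at this carbon. The 1-benzofuran-2-yl group still compares well with the two other groups, with a 4.1-fold lower number from compound 1 to compound 4 (0.61 log units; beyond the scatter) and an at least 4.4-fold lower number from compound 2 to compound 4 (0.64 log units; beyond the scatter). The second of these steps starts from a limit and not from a number: the limit of > 100000 nM in this assay, at which 1 of the 4 values shown sits.

Going by these compounds, what a thiophen-2-yl group, with sulfur in place of the furan oxygen, would give at this carbon stays open. So does the outcome of a methyl group or an amine on the furan.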